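Swapping 2-methylpyridin-4-yl for 3-fluoropyridin-4-yl

The source may hold more compounds than are shown below. What is called first, only, known or untested is meant among the compounds shown, and "the series" means these compounds.

Compound 1 `C[C@@H]1CN(C(=O)OC(C)(C)C)CCN1c1ncc(OCc2ccc(S(C)(=O)=O)cc2F)cn1` reads < 5000 nM in a physicochemical assay for solubility, in phosphate buffer, at pH 7.4 (on this read-out lower numbers stand for lower solubility and higher numbers for higher solubility), and this is a limit of the assay, not a number. Among the compounds with values here, compound 2 `Cc1cc(COc2cnc(N3CCN(C(=O)OC(C)(C)C)CC3)nc2)ccn1` gives 66000 nM in this assay, the only true number so far. Compound 3 `CC(C)(C)OC(=O)N1CCN(c2ncc(OCc3ccncc3F)cn2)CC1` carries 3-fluoropyridin-4-yl in place of 2-methylpyridin-4-yl on a saturated chain carbon bound to an oxygen on an aromatic ring. Within the data shown here, no measured pair covers this change, so the expected step of a 1.3-fold lower number from compound 2 to compound 3 (0.12 log units; within the scatter) is none beyond the usual scatter. For compound 3 the estimated value is 50000 nM, with an expected range from 15000 nM to 130000 nM (still to be measured).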

Compound 3, solubility: 5100 nM
The estimate for compound 3 lay 9.8-fold (0.99 log units) above the measured number, outside the stated range (below it).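

At this position the read-out moves strongly in this assay: swapping 2-methylpyridin-4-yl for 3-fluoropyridin-4-yl gives a 13-fold lower number from compound 2 to compound 3 (1.11 log units; beyond the scatter). Both groups have the same counts of heavy atoms, hydrogen-bond donors and acceptors, so these counts alone do not track the change. Compound 1 carries the one value that is a limit, not a number: the limit of < 5000 nM in this assay, at which 1 of the 3 values shown sits.

The swap removes a methyl and adds a fluorine together, so it remains open which of the two accounts for the step. A plain pyridin-4-yl in this place would separate them, and an aminopyridine would test a different group there.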